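This account rests on a few compounds, and the source may have more. Where it says the series, first, only, none or still open, it means among the compounds named here.

Measured compounds, with the number each gives in a functional assay on NCI-H460 cells (Homo sapiens) for inhibition, read by MTT assay, with a stated time of 72 h; on this read-out lower numbers stand for stronger inhibition and higher numbers for weaker inhibition:
compound 1 `COc1cc2c(Oc3ccc(NC(=O)c4nn(-c5ccccc5C(F)(F)F)c(=O)cc4C)cc3F)ccnc2cc1OCCCN1CCCCC1`: 210 nM
compound 2 `COc1cc2c(Oc3ccc(NC(=O)c4nn(-c5ccccc5C(F)(F)F)c(=O)cc4C)cc3F)ccnc2cc1OCCCN1CCC(C)CC1`: 200 nM
compound 3 `COc1cc2c(Oc3ccc(NC(=O)c4nn(-c5cccc(F)c5)c(=O)cc4C)cc3F)ccnc2cc1OCCCN1CCCCC1`: 360 nM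

Compound 4 `COc1cc2c(Oc3ccc(NC(=O)c4nn(-c5cccc(F)c5)c(=O)cc4C)cc3F)ccnc2cc1OCCCN1CCC(C)CC1` is not yet measured. Compound 4 stands to compound 3 as compound 2 stands to compound 1. The change from compound 1 to compound 2 is methyl in place of hydrogen on a saturated ring carbon, and in this assay it gave a 1.1-fold lower number from compound 1 to compound 2 (0.02 log units; within the scatter). The change from compound 3 to compound 4 is methyl in place of hydrogen on a saturated ring carbon; the place is described in the same words for both pairs, so this is the same change made on a second core. The two cores differ by 3-fluorophenyl in place of 2-(trifluoromethyl)phenyl on an aromatic nitrogen, a difference that in this assay reads a 1.7-fold higher number from compound 1 to compound 3 (0.23 log units; within the scatter).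

Among the measured compounds shown here, since the one earlier instance of this change moved the number by a 1.1-fold lower number from compound 1 to compound 2 (0.02 log units; within the scatter), the step from compound 3 to compound 4 in this assay is expected to be about as small, roughly a 1.1-fold lower number from compound 3 to compound 4 (0.04 log units; within the scatter), because compound 3 starts at 360 nM. Compound 4 is therefore estimated at 330 nM, likely between 170 nM and 700 nM.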

Compound 4, half-maximal inhibitory concentration: 250 nM
Estimate against measurement, compound 4: 1.3-fold (0.12 log units) above; measured number inside the range.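

In this assay, piperidin-1-yl to 4-methylpiperidin-1-yl on the 3-fluorophenyl core gives a 1.4-fold lower number from compound 3 to compound 4 (0.16 log units; within the scatter), and exchanging the aryl group on the 4-methylpiperidin-1-yl side gives a 1.3-fold higher number from compound 2 to compound 4 (0.10 log units; within the scatter). The methyl step agrees across the two cores: the same change on two cores in this assay, a 1.1-fold lower number (0.02 log units; within the scatter) from compound 1 to compound 2 and a 1.4-fold lower number (0.16 log units; within the scatter) from compound 3 to compound 4, 1.4-fold (0.14 log units) apart, within the scatter of two such steps. With steps this small, the agreement shows only that the methyl leaves the number within the scatter on both of these cores, not that a larger step would carry over from one core to the other, and the aryl exchange reads the same way on the two amines: the same change on two cores in this assay, a 1.7-fold higher number (0.23 log units; within the scatter) from compound 1 to compound 3 and a 1.3-fold higher number (0.10 log units; within the scatter) from compound 2 to compound 4, 1.4-fold (0.14 log units) apart, within the scatter of two such steps.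

The compounds shown leave open whether this holds for a larger or more functionalised group at the same ring carbon, such as an ethyl, a hydroxyl or a dimethylamino group, or for a morpholine or an N-methylpiperazine in place of the piperidine. They also leave open whether the agreement extends to aryl groups beyond these two, such as an unsubstituted phenyl or a pyridine.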